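Quinolin-4-yl to 2-chloroquinolin-3-yl: working notes

The source may hold more compounds than are shown below. What is called first, only, known or untested is meant among the compounds shown, and "the series" means these compounds.

In an ADME assay on CHO cells (Cricetulus griseus) for cytotoxicity, read by MTT assay (on this read-out higher numbers stand for weaker inhibition and lower numbers for stronger inhibition), compound 1 `C=CCN1C[C@@H](OCc2ccccc2)[C@@H](CNCc2ccc3ccccc3n2)C(C)(C)C1` gives 211000 nM and compound 2 `C=CCN1C[C@@H](OCc2ccccc2)[C@@H](CNCc2ccnc3ccccc23)C(C)(C)C1` gives 139000 nM. For the measured compounds named here, these are the only two numbers so far, and they lie within the scatter of each other, so compound 2 holds no separate rank.

The next compound, compound 3 `C=CCN1C[C@@H](OCc2ccccc2)[C@@H](CNCc2cc3ccccc3nc2Cl)C(C)(C)C1`, keeps the shared core and carries 2-chloroquinolin-3-yl in place of quinolin-4-yl on a saturated chain carbon bound to an amine nitrogen.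

Going by the values given here, one measured step bears on this change. Quinolin-4-yl in place of quinolin-2-yl at the same place gave a 1.5-fold lower number from compound 1 to compound 2 (0.18 log units; within the scatter). Among the compounds with values here, that step involves no chlorine, and no measured compound carries one, so the data say nothing direct about that part of the change. Within the data shown here, the only precedent is a step inside the scatter, so no step beyond the scatter is expected in this assay, and the range is kept wide. The expected step is a 1.1-fold lower number from compound 2 to compound 3 (0.03 log units; within the scatter). For compound 3 the estimated value is 130000 nM, with an expected range from 60000 nM to 280000 nM.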

Compound 3, half-maximal inhibitory concentration: 199000 nM
Compound 3: middle estimate off by 1.5-fold (0.18 log units), on the low side; measured number inside the range.
By their numbers in this assay, from the lowest: compounds 2, 3 and 1 (each within the scatter of the next).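

In this assay the change to 2-chloroquinolin-3-yl on a saturated chain carbon bound to an amine nitrogen gives a 1.4-fold higher number from compound 2 to compound 3 (0.16 log units; within the scatter) and the same group in place of quinolin-2-yl gives a 1.1-fold lower number from compound 1 to compound 3 (0.03 log units; within the scatter) so neither step separates compound 3 from the other two compounds. For the compounds shown here, compound 3 is the first compound to carry chlorine, and with it the three quinoline groups at this place still form a single group of compounds with no rank among them, so neither the entry of the chlorine nor the change of attachment point on the quinoline shows a step beyond the scatter here. No supporting data are available to explain these small differences or to connect them to any property of the groups.

On these data alone, the step to compound 3 combines the chlorine with a new attachment point, and without plain quinolin-3-yl the share of each remains open. Also open, as far as these compounds go, is whether a group of another kind at this place, such as a carboxylic acid, a primary amine or a simple phenyl, would give a step beyond the scatter.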